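This account rests on a few compounds, and the source may have more. Where it says the series, first, only, none or still open, it means among the compounds named here.

Working notes on the series in a functional assay on MCF7 cells (Homo sapiens) for cytotoxicity, read by MTT assay, with a stated time of 24 h, tested at 32 ug/mL; a higher number here means a stronger effect of the compound at the concentration tested, a lower number a weaker effect.

Compound 1 `Cn1c(-c2ccc(NC(=O)CSc3nc4ccccc4s3)cc2)nc(-c2ccccc2)c1-c1ccccc1` gives 59% in this assay. Within the three measured compounds it stands second highest: compound 2 `Cn1nnnc1SCC(=O)Nc1ccc(-c2nc(-c3ccccc3)c(-c3ccccc3)n2C)cc1` gives 77.5%, a step of a number 18.5 percentage points higher from compound 1 to compound 2 (beyond the scatter), and compound 3 `CCN1CCN(CC(=O)Nc2ccc(-c3nc(-c4ccccc4)c(-c4ccccc4)n3C)cc2)CC1` gives 38.6%, a step of a number 20.4 percentage points lower from compound 1 to compound 3 (beyond the scatter). Both steps lie beyond the scatter, and the gap between compound 2 and compound 3, a number 38.9 percentage points lower from compound 2 to compound 3 (beyond the scatter), is the largest among the measured pairs.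

Compound 4 `CN(C)/C=C/N1CCN(CC(=O)Nc2ccc(-c3nc(-c4ccccc4)c(-c4ccccc4)n3C)cc2)CC1` is not yet measured. It differs from compound 1 as follows: 4-(2-(dimethylamino)ethenyl)piperazin-1-yl in place of (1,3-benzothiazol-2-yl)sulfanyl on a saturated chain carbon bound to a carbonyl carbon. Among the compounds with values here, the step that bears on this change is the one to compound 3, since compound 3 also carries a piperazin-1-yl at the same place, and that step, a number 20.4 percentage points lower from compound 1 to compound 3 (beyond the scatter), was a modest drop beyond the scatter. Within the data shown here, the substituent on the piperazine differs between compound 3 and compound 4, and no measured pair isolates that part of the change, so the expectation rests on compound 3 alone.

On that basis a step of about a number 19 percentage points lower from compound 1 to compound 4 (beyond the scatter) is expected, downward, beyond the scatter. For compound 4 a value of 40% is estimated, with a range from 22% to 58%.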

Compound 4, a percentage reported as activity, at one concentration (the size of the read-out at that concentration, not a potency): 25.8%
Compound 4: middle estimate off by 14.2 percentage points, on the high side; the range from low to high includes it.
By their numbers in this assay, from the lowest: compound 4; then compound 3; then compound 1; then compound 2.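

In this assay the substituent on the piperazine nitrogen turns out to matter: with 2-(dimethylamino)ethenyl in place of ethyl on an amine nitrogen in a ring, the change gives a number 12.8 percentage points lower from compound 3 to compound 4 (beyond the scatter). At the saturated chain carbon bound to a carbonyl carbon, the lower numbers no longer rest on compound 3 alone, as the second piperazine gives a number 33.2 percentage points lower from compound 1 to compound 4 (beyond the scatter) and a number 51.7 percentage points lower from compound 2 to compound 4 (beyond the scatter), so among these four compounds both sulfanyl groups stand above both piperazine groups, and no compound goes against that order. No measurement is at hand that bears on why the numbers move in this way.

As far as these compounds go, it remains open whether the step from ethyl depends on the double bond or on the dimethylamino group, a question that 2-(dimethylamino)ethyl on the same ring nitrogen would separate. Also open, from the compounds shown here alone, is how far the order of the four compounds holds for other groups at the chain carbon, such as morpholin-4-yl, and at other concentrations, since this read-out gives the size of the effect at one concentration and not a potency.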